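This account rests on a few compounds, and the source may have more. Where it says the series, first, only, none or still open, it means among the compounds named here.

Series notes. In a functional assay on cells (T-cell, Homo sapiens) for inhibition (on this read-out lower numbers stand for stronger inhibition and higher numbers for weaker inhibition), compound 3 `COc1ccc(-c2cnc3nc(N)nc(N4CCN(Cc5c(Cl)cccc5Cl)CC4)c3n2)cc1OC` gives 7600 nM, the highest of the three numbers in hand. Compound 1 `COc1ccc(-c2cnc3nc(N)nc(N4CCN(Cc5ccccc5F)CC4)c3n2)cc1OC` gives 700 nM and compound 2 `COc1ccc(-c2cnc3nc(N)nc(N4CCN(c5ccc(C)cc5)CC4)c3n2)cc1OC` gives 300 nM; the gaps are an 11-fold higher number from compound 1 to compound 3 (1.04 log units; beyond the scatter) and a 25-fold higher number from compound 2 to compound 3 (1.40 log units; beyond the scatter), both beyond the scatter, so compound 3 is the weakest of the three measured. The next compound, compound 4 `COc1ccc(-c2cnc3nc(N)nc(N4CCN(c5ccccc5)CC4)c3n2)cc1OC`, changes the group on the amine nitrogen in the ring: phenyl in place of 2,6-dichlorobenzyl on an amine nitrogen in a ring. The step most like this one is a 25-fold higher number from compound 2 to compound 3 (1.40 log units; beyond the scatter) read backwards; there too an aromatic ring on the amine nitrogen in the ring stands against the 2,6-dichlorobenzyl group, the difference being the methyl of compound 2. Compound 1 and compound 2 both sit far under compound 3, and a 2.3-fold lower number from compound 1 to compound 2 (0.37 log units; beyond the scatter) puts an aromatic ring on that nitrogen a little under a benzyl group. For compound 4 a large drop in the number is therefore expected in this assay, of about a 19-fold lower number from compound 3 to compound 4 (1.28 log units; beyond the scatter). Compound 4 is estimated at 400 nM, with a range of 150 nM to 1200 nM.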

Compound 4, half-maximal inhibitory concentration: 400 nM
Compound 4: the middle estimate sits on the measured number at the digits printed; the range from low to high includes it.
By their numbers in this assay, from the lowest: compounds 2, 4 and 1 (each within the scatter of the next, the first and the last beyond it); then compound 3.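

In this assay, a 19-fold lower number from compound 3 to compound 4 (1.28 log units; beyond the scatter) shows that an unsubstituted phenyl on the amine nitrogen in the ring is enough to close the large gap to the 2,6-dichlorobenzyl group. The methyl of the 4-methylphenyl group makes no readable difference, since a 1.3-fold higher number from compound 2 to compound 4 (0.12 log units; within the scatter) stays within the scatter. Phenyl and 2-fluorobenzyl also cannot be told apart at this position, given a 1.8-fold lower number from compound 1 to compound 4 (0.24 log units; within the scatter), so a benzyl group alone does not bring the weak result seen with compound 3. Still open, from the compounds shown here alone, is how an amine or a methoxy group on the phenyl ring, or a single chlorine on the benzyl group, would change the number. Nothing shown here gives a measured reason for these steps.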